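The source may report more compounds than this note shows. Statements on the series, on what has been measured and on what is new or still open speak of the compounds shown alone.

Measured compounds:
compound 1 `CC(C)(C)C1=NN(c2cccc(C(F)(F)F)c2)C(c2ccc(O)cc2)C1`: 2700 nM
compound 2 `Oc1ccc(C2CC(c3ccccc3O)=NN2c2cccc(Cl)c2)cc1F`: 2900 nM

In an assay on isolated protein for inhibition of protein kinase C zeta type (Homo sapiens), with a stated time of 4 min (on this read-out lower numbers stand for stronger inhibition and higher numbers for weaker inhibition), compound 1 gives 2700 nM. In this assay compound 2 gives 2900 nM. Compound 2 stands beside compound 1 on these two numbers: the two values lie within the usual scatter of each other, so the data give no separation between them.

Compound 3 `Oc1ccccc1C1=NN(c2cccc(Cl)c2)C(c2cc(F)c(O)c(F)c2)C1` differs from compound 2 in one place: fluoro in place of hydrogen on an aromatic carbon. Going by the values given here, no step between measured compounds of this kind is available, so the effect of this change has to be guessed from compound 2 alone. The expectation is that the step from compound 2 to compound 3 is small, with no direction that stands out beyond the scatter of this assay, and it is estimated as a 1.2-fold lower number from compound 2 to compound 3 (0.06 log units; within the scatter). Compound 3 is therefore expected to give about 2500 nM in this assay, with a range from 1100 nM to 6000 nM.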

Compound 3, half-maximal inhibitory concentration: 11100 nM
The estimate for compound 3 lay 4.4-fold (0.65 log units) below the measured number; measured number above the stated range.
By their numbers in this assay, from the lowest: compounds 1 and 2 (each within the scatter of the next); then compound 3.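

In this assay, going by these compounds alone, the change from 3-fluoro-4-hydroxyphenyl to 3,5-difluoro-4-hydroxyphenyl gives a 3.8-fold higher number from compound 2 to compound 3 (0.58 log units; beyond the scatter), the first single-place change and one that lies beyond the scatter. This position, ortho to a hydroxy group, is therefore not indifferent to its substituent: in this one pair, fluoro in place of hydrogen weakens inhibition. No measurement shown here accounts for this step.

With only hydrogen and fluoro shown at this position, it remains open whether a methyl, a methoxy or an amine there would also weaken inhibition, or whether the loss is specific to fluoro. On these data alone, it is also open whether the same change would have a similar effect in a compound carrying the other substituents of compound 1.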